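Shifting the chlorines on the benzamide ring of compound 3

The source may report more compounds than this note shows. Statements on the series, on what has been measured and on what is new or still open speak of the compounds shown alone.

Compound 1 `O=C(Nc1ccc(Cl)c(-c2nnc3c(Cl)cccn23)c1)c1ccc(F)cc1Cl`: > 100000 nM
Compound 2 `O=C(Nc1ccc(Cl)c(-c2nnc3c(Cl)cccn23)c1)c1ccccn1`: > 100000 nM
Compound 3 `O=C(Nc1ccc(Cl)c(-c2nnc3c(Cl)cccn23)c1)c1cccc(Cl)c1`: 54800 nM

In a functional assay on MDA-MB-468 cells (Homo sapiens) for antiproliferative activity, read by MTT assay, with a stated time of 72 h (a lower number here means a stronger inhibitor, a higher number a weaker inhibitor), compound 3 is the only one of the three with a number rather than a limit. Compound 1 sits at a limit (the limit of > 100000 nM in this assay, at which 2 of the 3 values shown sit). Compound 2 also sits at that limit. The step of an at least 1.8-fold lower number from compound 1 to compound 3 (0.26 log units; that floor lies within the scatter) and the step of an at least 1.8-fold lower number from compound 2 to compound 3 (0.26 log units; that floor lies within the scatter) are both floors within the scatter. Compound 4 `O=C(Nc1ccc(Cl)c(-c2nnc3c(Cl)cccn23)c1)c1ccc(Cl)cc1Cl` carries the change (2,4-dichlorophenyl in place of 3-chlorophenyl on a carbonyl carbon), which brings back a 2-chloro pattern like that of compound 1. In this assay compound 4 is therefore expected to give 90000 nM (range 30000 nM to 300000 nM). The expected step is a 1.6-fold higher number from compound 3 to compound 4 (0.22 log units; within the scatter), towards weaker activity, likely reaching the limit.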

Compound 4, half-maximal inhibitory concentration: 21600 nM
Estimate against measurement, compound 4: 4.2-fold (0.62 log units) above, outside the stated range (below it).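

The 2,4-dichlorophenyl group gives the first step from compound 3 that lies beyond the scatter, a 2.5-fold lower number from compound 3 to compound 4 (0.40 log units; beyond the scatter) in this assay. Exchanging a single fluoro for chloro on an aromatic carbon is enough to bring activity into the measurable range, an at least 4.6-fold lower number from compound 1 to compound 4 (0.66 log units; beyond the scatter), and replacing pyridin-2-yl with this group gives an at least 4.6-fold lower number from compound 2 to compound 4 (0.66 log units; beyond the scatter). These last two steps are floors, since they start from a limit: the limit of > 100000 nM in this assay, at which 2 of the 4 values shown sit.

Going by these compounds, how far those two steps truly reach remains open. So does whether a bromo or methoxy group in place of that chloro would give a lower number.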